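Swapping a Bromomethyl Ketone for an Epoxide

The compounds below may be only part of what the source reports. "The series", "measured", "known", "first", "only" and "open" are said of these compounds alone.

Measured in an ADME assay for pharmacokinetics, read by LC-MS, in phosphate buffer, with a stated time of 72 h, at pH 7.4, tested at 250 uM; on this read-out higher numbers stand for a longer-lived compound and lower numbers for a shorter-lived compound:
Compound 1 `C=Cc1cc(C(F)(F)F)cc(C(F)(F)F)c1`: > 50 h, a limit of the assay
Compound 2 `N#Cc1cc(C(F)(F)F)cc(C(F)(F)F)c1`: 50 h
Compound 3 `O=C(CBr)c1cc(C(F)(F)F)cc(C(F)(F)F)c1`: < 0.017 h, a limit of the assay

Compound 3 sits at the limit of < 0.017 h in this assay, at which 1 of the 3 values shown sits, the lowest of the values shown, and its reading is a limit rather than a number. Compound 2 gives 50 h. Compound 1 sits at the limit of > 50 h in this assay, at which 1 of the 3 values shown sits, also a limit. Both measured steps onto the (bromomethyl)carbonyl, an at least 2900-fold lower number from compound 1 to compound 3 (3.46 log units; beyond the scatter) and an at least 2900-fold lower number from compound 2 to compound 3 (3.46 log units; beyond the scatter), are large and downward. Compound 4 `FC(F)(F)c1cc(C2CO2)cc(C(F)(F)F)c1` removes that group: oxiran-2-yl in place of (bromomethyl)carbonyl on an aromatic carbon. Going by the values given here, no measured compound carries an oxiran-2-yl, so the exact size of the reverse step stays open; what is expected is a large rise, an at least 1700-fold higher number from compound 3 to compound 4 (3.24 log units; beyond the scatter), back toward the longer-lived compounds. Compound 4 is therefore estimated at 30 h, with a range of 5 h to 100 h.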

Compound 4, half-life: > 50 h
Compound 4: only a limit was reported (the forecaster's own chance of this, stated with the estimate: 30%); middle value at least 1.6-fold (0.22 log units) from the limit.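

At this position, oxiran-2-yl in place of (bromomethyl)carbonyl gives an at least 2900-fold higher number from compound 3 to compound 4 (3.46 log units; beyond the scatter) and so joins vinyl and cyano on the long-lived side. In this assay compound 4 gives > 50 h as a limit of the assay. Oxiran-2-yl in place of cyano gives a number no lower from compound 2 to compound 4 (the limit leaves the size open) and the size of that step stays open. The step from compound 1 to compound 4 cannot be read.

The compounds shown leave open how far this result extends to other groups at this position, such as a chloromethyl ketone or an amine.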